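The source may hold more compounds than are shown below. What is called first, only, known or untested is meant among the compounds shown, and "the series" means these compounds.

In an ADME assay on a cell-free system (plasma, Rattus norvegicus) for metabolic stability, read by LC-MS, with a stated time of 1 h, at 37 degrees C, tested at 100 uM (on this read-out lower numbers stand for a less stable compound and higher numbers for a more stable compound), compound 1 (`CN(C)C(=O)c1cc(-c2cccc(COc3ccc4c(=O)n(C5CCCC5)sc4c3)c2)ccc1Cl`) has 100% remaining, compound 2 (`O=C(O)c1cc(-c2cccc(COc3ccc4c(c3)CN(C3CCCC3)C4=O)c2)ccc1O`) has 98% remaining and compound 3 (`CC(C)CCn1sc2cc(OCc3cccc(-c4ccc(Cl)c(C(=O)O)c4)c3)ccc2c1=O`) has 91% remaining. These three numbers lie within the usual scatter of one another, so compound 2 stands level with the other two. Compound 4 (`O=C(O)c1ccc(-c2cccc(COc3ccc4c(c3)CN(C3CCCC3)C4=O)c2)c(Cl)c1`) keeps the core of compound 2 but swaps one end group (4-carboxy-2-chlorophenyl in place of 3-carboxy-4-hydroxyphenyl on an aromatic carbon) with 4-carboxy-2-chlorophenyl in place of 3-carboxy-4-hydroxyphenyl on an aromatic carbon. Among the compounds with values here, no measured pair shows this swap alone. Compound 3 also carries a carboxy group and a chlorine and has 91% remaining, so no step beyond the scatter is expected in this assay for this change. The expected change is a number 3 percentage points lower from compound 2 to compound 4 (within the scatter) and stays within the scatter. Compound 4 is estimated at 95% within a range from 82% to 100% remaining.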

Compound 4, percent of the compound remaining: 100%
Compound 4: middle estimate off by 5 percentage points, on the low side; the measured number falls inside the stated range.
By their numbers in this assay, from the lowest: compounds 3, 2, 1 and 4 (each within the scatter of the next).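

In this assay, the swap of 3-carboxy-4-hydroxyphenyl for 4-carboxy-2-chlorophenyl gives a number 2 percentage points higher from compound 2 to compound 4 (within the scatter), the first step read between two compounds that differ in one place. On this aromatic carbon, the two end groups therefore stand level on the shared core, so plasma stability here does not separate a ring carrying a hydroxy group from one carrying a chlorine. From the compounds shown here alone, whether an amine or a tetrazole in place of the carboxylic acid on this ring would stay level remains open. Nothing measured here gives a reason for this result.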